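The source may hold more compounds than are shown below. What is called first, only, known or untested is meant among the compounds shown, and "the series" means these compounds.

Measured compounds:
- compound 1, `O=C(Nc1cccc(-n2cc(-c3ccncc3)c(-c3ccc(Cl)c(O)c3)n2)c1)Nc1cccc(C(F)(F)F)c1`: 950 nM
- compound 2, `COc1cc(-c2nn(-c3cccc(NC(=O)Nc4cc(C(F)(F)F)cc(C(F)(F)F)c4)c3)cc2-c2ccncc2)ccc1Cl`: 250 nM
- compound 3, `COc1cc(-c2nn(-c3cccc(NC(=O)Nc4cccc(C(F)(F)F)c4)c3)cc2-c2ccncc2)ccc1Cl`: 370 nM

In a functional assay on PC-3 cells (Homo sapiens) for inhibition, read by sulforhodamine B assay, with a stated time of 48 h (on this read-out lower numbers stand for stronger inhibition and higher numbers for weaker inhibition), compound 2 gives the lowest of the three numbers; compound 3 sits closest to it, with a 1.5-fold higher number from compound 2 to compound 3 (0.17 log units; within the scatter), a gap within the scatter, so no order between those two can be claimed, while compound 1 lies furthest away, beyond the scatter. Compound 4, `O=C(Nc1cccc(-n2cc(-c3ccncc3)c(-c3ccc(Cl)c(O)c3)n2)c1)Nc1cc(C(F)(F)F)cc(C(F)(F)F)c1`, has not yet been measured. It differs from compound 2 by hydrogen in place of methyl on an oxygen on an aromatic ring. Within the data shown here, one measured step bears directly on this change, in the opposite direction: a 2.6-fold lower number from compound 1 to compound 3 (0.41 log units; beyond the scatter), a modest step beyond the scatter when methyl replaced hydrogen on that oxygen. Reversing it, the expectation for compound 4 is a modest rise in the number, about a 2.6-fold higher number from compound 2 to compound 4 (0.41 log units; beyond the scatter), rather than a step within the scatter. Compound 4 is therefore estimated at 650 nM, with a likely range from 300 nM to 1400 nM.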

Compound 4, half-maximal inhibitory concentration: 320 nM
For compound 4 the middle estimate is 2.0-fold (0.31 log units) above the measured one, within the range that was stated.
By their numbers in this assay, from the lowest: compounds 2, 4 and 3 (each within the scatter of the next); then compound 1.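

In this assay, methoxy to hydroxy gives no readable difference on the core of compound 2, with a 1.3-fold higher number from compound 2 to compound 4 (0.11 log units; within the scatter), although the same change lay beyond the scatter on the core of compound 3. Trifluoromethyl in place of hydrogen on an aromatic carbon had stayed within the scatter on the methoxy pair, but on the hydroxy pair it gives a 3.0-fold lower number from compound 1 to compound 4 (0.47 log units; beyond the scatter). Neither contrast is firm, so the four compounds show no secure dependence of one change on the other, as the first comparison shows: the same change on two cores in this assay, a 2.6-fold lower number (0.41 log units; beyond the scatter) from compound 1 to compound 3 and a 1.3-fold lower number (0.11 log units; within the scatter) from compound 4 to compound 2, 2.0-fold (0.30 log units) apart, within the scatter of two such steps. The second comparison reads the same way: the same change on two cores in this assay, a 1.5-fold higher number (0.17 log units; within the scatter) from compound 2 to compound 3 and a 3.0-fold higher number (0.47 log units; beyond the scatter) from compound 4 to compound 1, 2.0-fold (0.30 log units) apart, within the scatter of two such steps.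

On these data alone, what stays open is whether the methoxy to hydroxy change matters beyond the pair of compound 1 and compound 3. As far as these compounds go, how an ethoxy group or an amine in place of the methoxy would read in this assay also remains open.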